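Swapping the Aryl Amide Group on a Shared Core

This account rests on a few compounds, and the source may have more. Where it says the series, first, only, none or still open, it means among the compounds named here.

Two measured compounds share one core and differ only in the aryl group attached to the amide carbonyl. Compound 1 `COc1ccc(C(=O)Nc2cccc(-c3ccnc4c(NC(C)=O)cccc34)c2)cc1OC` carries a 3,4-dimethoxyphenyl there; in a functional assay on SK-MEL-28 cells (Homo sapiens) for antiproliferative activity, read by sulforhodamine B assay, with a stated time of 48 h (on this read-out higher numbers stand for weaker inhibition and lower numbers for stronger inhibition), compound 1 gives 2700 nM. Compound 2 `CC(=O)Nc1cccc2c(-c3cccc(NC(=O)c4ccc(Cl)c(C(F)(F)F)c4)c3)ccnc12` carries a 4-chloro-3-(trifluoromethyl)phenyl instead; in this assay compound 2 gives 3500 nM. The step of a 1.3-fold higher number from compound 1 to compound 2 (0.11 log units; within the scatter) is too small for the two numbers to be told apart, so compound 2 sits at the higher of the two numbers only by a margin that repeated measurement would blur.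

Compound 3 `CC(=O)Nc1cccc2c(-c3cccc(NC(=O)c4ccc5c(c4)OCCO5)c3)ccnc12` has not yet been measured. It differs from compound 2 in one place: 2,3-dihydro-1,4-benzodioxin-6-yl in place of 4-chloro-3-(trifluoromethyl)phenyl on a carbonyl carbon. Within the data shown here, the only measured step that bears on this position is a 1.3-fold higher number from compound 1 to compound 2 (0.11 log units; within the scatter), and it stayed within the scatter. Among the measured compounds shown here, since one exchange of the aryl group on this carbonyl produced no clear change, a further exchange is expected to behave alike, with no step in this assay beyond the scatter in either direction. For compound 3 the expected step is a 1.2-fold lower number from compound 2 to compound 3 (0.08 log units; within the scatter). Compound 3 is therefore estimated at 2900 nM, with a range from 1200 nM to 7500 nM.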

Compound 3, half-maximal inhibitory concentration: > 20000 nM
Compound 3: only a limit was reported; the forecaster's own chance of this, stated with the estimate: 5%; at least 6.8-fold (0.83 log units) between middle value and limit.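

Exchanging 4-chloro-3-(trifluoromethyl)phenyl for 2,3-dihydro-1,4-benzodioxin-6-yl gives an at least 5.7-fold higher number from compound 2 to compound 3 (0.75 log units; beyond the scatter), so this position does respond to the aryl group it carries, which compounds 1 and 2 alone could not show. The 3,4-dimethoxyphenyl group also carries oxygen on its aromatic ring, yet it cannot be interchanged with the entering group, as the exchange gives an at least 7.4-fold higher number from compound 1 to compound 3 (0.86 log units; beyond the scatter); tying the oxygens into a six-membered non-aromatic ring therefore goes with a clear loss of activity in this series, even though two very different aryl groups had left the number unmoved. In this assay compound 3 gives only a limit and not a number: the limit of > 20000 nM in this assay, at which 1 of the 3 values shown sits.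

The compounds shown cannot separate the effect of the non-aromatic ring itself from that of the oxygens it holds, and they give no reason for the loss. On these data alone, it also stays open whether an amine or a carboxylic acid on this aryl group would keep the activity of compound 1 or lose it as compound 3 does.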